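Shifting the chlorophenyl pattern in a benzimidazole acid series

The compounds below may be only part of what the source reports. "The series", "measured", "known", "first", "only" and "open" are said of these compounds alone.

Three compounds share one core and were tested in an assay on isolated protein for inhibition of protein kinase C zeta type (Homo sapiens), read by 33P incorporation, tested at 200 uM; a higher number here means a stronger effect of the compound at the concentration tested, a lower number a weaker effect. Compound 1 `O=C(O)CC(Cc1nc2cc(Cl)ccc2[nH]1)c1ccc(Cl)cc1` gives 70% in this assay. Compound 2 `O=C(O)CC(Cc1nc2cc(I)ccc2[nH]1)c1cccc(Cl)c1` gives 70%. Compound 3 `O=C(O)CC(Cc1nc2cc(Cl)ccc2[nH]1)c1ccc(Cl)cc1Cl` gives 80%, the highest of the three numbers, although the values of compound 1 and compound 2 both lie within the scatter of it. Among the compounds with values here, the only single-point step measured so far is a number 10 percentage points higher from compound 1 to compound 3 (within the scatter), a change that did not move the read-out beyond its scatter.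

Compound 4 `O=C(O)CC(Cc1nc2cc(Cl)ccc2[nH]1)c1cccc(Cl)c1` has not yet been measured. It differs from compound 3 by 3-chlorophenyl in place of 2,4-dichlorophenyl on a saturated chain carbon bound to two saturated chain carbons. Within the data shown here, no measured step exchanges one chlorophenyl pattern for another on the core of compound 3, so the step from compound 1 to compound 3 is the only guide to how much a chlorine count on this phenyl can shift the number, and it stayed within the scatter. The same 3-chlorophenyl as in compound 4 sits on a different core in compound 2, which gives 70%, a number within the scatter of compound 3.

Compound 4 is therefore expected to show a number 10 percentage points lower from compound 3 to compound 4 (within the scatter), a step not expected to exceed the scatter. The estimate for compound 4 is 70%, with a range of 55% to 85%.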

Compound 4, a percentage reported as inhibition, at one concentration (the size of the read-out at that concentration, not a potency): 0%
Compound 4: middle estimate off by 70 percentage points, on the high side; measured number outside the range, below it.
By their numbers in this assay, from the lowest: compound 4; then compounds 1, 2 and 3 (each within the scatter of the next).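

The steps at this position are far larger than the earlier one: in this assay, 3-chlorophenyl on a saturated chain carbon bound to two saturated chain carbons gives a number 80 percentage points lower from compound 3 to compound 4 (beyond the scatter) when it replaces 2,4-dichlorophenyl, and a number 70 percentage points lower from compound 1 to compound 4 (beyond the scatter) when it replaces 4-chlorophenyl, whereas a number 10 percentage points higher from compound 1 to compound 3 (within the scatter) had shown this phenyl tolerating a change. The 3-chlorophenyl does not erase the read-out on every core, since chloro in place of iodo on an aromatic carbon gives a number 70 percentage points lower from compound 2 to compound 4 (beyond the scatter), so among these compounds the outcome for this phenyl depends on the halogen on the core as well. Nothing available explains either loss.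

From the compounds shown here alone, it remains open whether iodo on the core would also hold the read-out with 4-chlorophenyl or 2,4-dichlorophenyl, and whether bromo at that aromatic carbon would behave like iodo or like chloro. A plain phenyl on the chain carbon would show whether the 3-chlorophenyl itself costs the read-out or whether the other two chlorine patterns supply it.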